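The source may hold more compounds than are shown below. What is called first, only, known or untested is meant among the compounds shown, and "the series" means these compounds.

Three esters of a cinnamic acid with an aryl-amide tail have been run through a functional assay on PC-3 cells (Homo sapiens) for cytotoxicity, read by MTT assay, with a stated time of 72 h; a lower number here means a stronger inhibitor, a higher number a weaker inhibitor. Compound 1 `COCOc1cc(/C=C/C(=O)OCC(=O)Nc2ccc(OC)cc2)ccc1OCc1ccccc1` and compound 2 `COCOc1cc(/C=C/C(=O)OCC(=O)Nc2ccc(Cl)cc2)ccc1OCc1ccccc1` share one core, while compound 3 `O=C(COC(=O)/C=C/c1ccc(O)c(O)c1)Nc1ccc(Cl)cc1` carries a different one; the difference between the two cores is not broken down here.

For compound 1 this assay reports only a limit, > 200000 nM. For compound 2 it likewise reports only a limit, > 200000 nM. The change from compound 2 to compound 1, (methoxy in place of chloro on an aromatic carbon), therefore yields a step that the two limits leave unreadable from compound 2 to compound 1, because of the limit of > 200000 nM in this assay, at which 2 of the 3 values shown sit.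

Within the data shown here, compound 3 is the one member of the set with a number rather than a limit: in this assay compound 3 gives 160000 nM.

Compound 4 `COc1ccc(NC(=O)COC(=O)/C=C/c2ccc(O)c(O)c2)cc1` has not yet been measured. It stands to compound 3 as compound 1 stands to compound 2: the change is methoxy in place of chloro on an aromatic carbon, the same change as before, made on the core of compound 3. Since the measured pair leaves the size of this change unreadable, the expectation for compound 4 rests on compound 3 and its value 160000 nM alone, with the step from compound 3 to compound 4 expected to be a 1.1-fold higher number from compound 3 to compound 4 (0.05 log units; within the scatter). Compound 4 is accordingly estimated to give about 180000 nM in this assay, most likely between 80000 nM and 400000 nM, with a real chance that only a limit is returned.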

Compound 4, half-maximal inhibitory concentration: 172000 nM
Compound 4: middle estimate off by 1.0-fold (0.02 log units), on the high side, and the stated range covers the measured number.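

On the second core, in this assay, putting methoxy in place of chloro gives a 1.1-fold higher number from compound 3 to compound 4 (0.03 log units; within the scatter), so 4-chlorophenyl and 4-methoxyphenyl cannot be told apart by this reading on that core. This does not show that the change behaves alike on both cores, since a single readable step on one core offers nothing to set beside it. The matching step from compound 2 to compound 1 cannot be read, because both of those compounds sit at a limit of the assay and neither has a number: the limit of > 200000 nM in this assay, at which 2 of the 4 values shown sit.

The compounds shown leave open whether any other group on that aromatic carbon, such as an amine, a carboxylic acid or a longer chain, would give a number in this assay that stands beyond the scatter from those of compound 3 and compound 4. They also leave open how much the core itself contributes, since no pair shown differs in the core alone, and the gap between the limits of compound 1 and compound 2 and the numbers of compound 3 and compound 4 cannot be assigned to any one part of the structure.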